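A few compounds are considered here, and "the series" means these few. Any claim that something is new, unique, unknown or untested is made for them only; others in the source may bear on it.

Measured compounds in the series:

Compound 1 `CC(C)n1ncc2c(C(=O)NCc3cn(-c4cccc(Br)c4)nn3)cccc21` – in a functional assay on MCF7 cells (Homo sapiens) for inhibition, read by MTT assay, with a stated time of 72 h (a lower number here means a stronger inhibitor, a higher number a weaker inhibitor), compound 1 gives > 40000 nM, a limit of the assay.
Compound 2 `Cc1ccc(-n2cc(CNC(=O)c3cccc4c3cnn4C(C)C)nn2)cc1` – in this assay compound 2 gives > 40000 nM, likewise a limit.

Compound 2 therefore stands only at a limit, with no number of its own. Going by the values given here, both values shown sit at the same limit (the limit of > 40000 nM in this assay, at which 2 of the 2 values shown sit), so the one measured step, a step that the two limits leave unreadable from compound 1 to compound 2, cannot be read in size or direction. The step from compound 2 to compound 3 changes the aryl group on the triazole nitrogen: 2-methylphenyl in place of 4-methylphenyl on an aromatic nitrogen. Compound 3 is `Cc1ccccc1-n1cc(CNC(=O)c2cccc3c2cnn3C(C)C)nn1`.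

Among the compounds with values here, nothing measured bears readably on this change: the only step in the set, from compound 1 to compound 2, is hidden behind two limits, and no compound with a numerical value exists. The change is a rearrangement of the same atoms within the methylphenyl group, and with compound 2 at the limit, the expectation is that compound 3 will also be reported only as a limit. The step of a number no higher from compound 2 to compound 3 (the limit leaves the size open) is thus expected to be none beyond the scatter, and compound 3 is estimated at 40000 nM, between 20000 nM and 80000 nM, most likely as a limit again.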

Compound 3, half-maximal inhibitory concentration: > 40000 nM
Compound 3 was reported as a limit; the forecaster's own chance of this, stated with the estimate: 85%; the middle value lies on the limit itself.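

In this assay compound 3 gives > 40000 nM, a limit of the assay. No step among compound 1, compound 2 and compound 3 can be read in size or direction, because all three stand at one limit: the limit of > 40000 nM in this assay, at which 3 of the 3 values shown sit.

Open remains whether 3-bromophenyl, 4-methylphenyl and 2-methylphenyl on the aromatic nitrogen differ at all in this assay.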